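Acetylation of the allylic alcohol in the cyclohexenyl sulfone series

A few compounds are considered here, and "the series" means these few. Any claim that something is new, unique, unknown or untested is made for them only; others in the source may bear on it.

Measured so far in a functional assay on RAW264.7 cells (Mus musculus), read by fluorescence; on this read-out lower numbers stand for stronger inhibition and higher numbers for weaker inhibition:
compound 1, `COC(=O)C1=CCCCC1S(=O)(=O)Cc1ccc(F)cc1Cl`, 99 nM
compound 2, `O=S(=O)(Cc1ccc(F)cc1Cl)C1CCCC=C1CO`, > 10000 nM

Compound 2 stands at the weak end of the two numbers shown. Its value in this assay is a limit of the assay, not a number; this is the limit of > 10000 nM in this assay, at which 1 of the 2 values shown sits. For the measured compounds named here, the only measured step here is an at least 100-fold higher number from compound 1 to compound 2 (2.00 log units; beyond the scatter), which shows that replacing the methoxycarbonyl of compound 1 with hydroxymethyl costs most of the inhibition.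

Compound 3, `CC(=O)OCC1=CCCCC1S(=O)(=O)Cc1ccc(F)cc1Cl`, differs from compound 2 by acetyl in place of hydrogen on an oxygen on a saturated carbon. That change reintroduces a carbonyl-bearing ester, although as acetoxymethyl rather than as methoxycarbonyl on the ring carbon, so the measured step bears on it only partly. Some recovery from the limit of compound 2 is expected, but not the full return to the level of compound 1, given the size of an at least 100-fold higher number from compound 1 to compound 2 (2.00 log units; beyond the scatter). For compound 3 a value of 3000 nM is estimated, with a range from 300 nM to 15000 nM, corresponding to an expected step of an at least 3.3-fold lower number from compound 2 to compound 3 (0.52 log units; beyond the scatter).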

Compound 3, half-maximal inhibitory concentration: > 10000 nM
Compound 3 gave a limit, no number (the forecaster's own chance of this, stated with the estimate: 40%); middle value at least 3.3-fold (0.52 log units) from the limit.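

In this assay compound 3 gives > 10000 nM, a limit of the assay and not a number. Acetoxymethyl on the double-bonded ring carbon does not restore what methoxycarbonyl gives at this place, with an at least 100-fold higher number from compound 1 to compound 3 (2.00 log units; beyond the scatter), so an ester as such is not enough here and the form of the ester matters. Acetyl on the oxygen brings no recovery that this read-out can show, and the step from hydroxymethyl to acetoxymethyl cannot be read: the limit of > 10000 nM in this assay, at which 2 of the 3 values shown sit.

Open, on these data alone, is whether a carboxylic acid, a primary amide or an ethyl ester on the same ring carbon keeps the inhibition seen with compound 1. Also open, as far as these compounds go, is how far compound 2 and compound 3 lie past the limit, so no order between hydroxymethyl and acetoxymethyl can be given.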